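The source may report more compounds than this note shows. Statements on the series, on what has been measured and on what is new or still open speak of the compounds shown alone.

Values so far in a functional assay on Caudal artery for antagonist activity at Alpha-1A adrenergic receptor (Rattus norvegicus); on this read-out lower numbers stand for stronger inhibition and higher numbers for weaker inhibition:

compound 1 `COC(=O)[C@@H]1c2cc(/C=C/C(=O)NCCCCNC(=N)N)ccc2O[C@H]1c1ccc(O)cc1` – 9720000 nM
compound 2 `N=C(N)NCCCCNC(=O)/C=C/c1ccc2c(c1)[C@@H](C(=O)NCCCCNC(=N)N)[C@H](c1ccc(O)cc1)O2` – 14300000 nM
compound 3 `N=C(N)NCCCCNC(=O)/C=C/c1ccc2c(c1)[C@@H](C(=O)NCCCCNC(=N)N)[C@@H](c1ccc(O)cc1)O2` – 17700000 nM

Compound 2 holds the second-highest of the three numbers in this assay. Both measured steps, a 1.5-fold higher number from compound 1 to compound 2 (0.17 log units; within the scatter) and a 1.2-fold higher number from compound 2 to compound 3 (0.09 log units; within the scatter), stay within the scatter, so the three measured compounds are not separated on this read-out. The second of these steps rests on drawing alone: the fact that one of compounds 2 and 3 is drawn with a defined configuration and the other without, at the place where they differ.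

Compound 4 `N=C(N)NCCCCNC(=O)[C@@H]1c2cc(/C=C/C(=O)O)ccc2O[C@H]1c1ccc(O)cc1` differs from compound 2 as follows: one oxygen atom in place of a group of 9 heavy atoms (5 carbon, 4 nitrogen; no ring), on a carbonyl carbon. Among the measured compounds shown here, no measured step touches this carbonyl carbon. For the measured compounds named here, the nearest precedent is the exchange between compound 1 and compound 2, where a group of the same kind was put in on a carbonyl carbon elsewhere in the structure, and that step, a 1.5-fold higher number from compound 1 to compound 2 (0.17 log units; within the scatter), did not leave the scatter. The stereochemical step between compound 2 and compound 3 has no bearing on the present change.

On this basis no step beyond the scatter is expected from compound 2 to compound 4; the estimated step is a 1.0-fold lower number from compound 2 to compound 4 (0.01 log units; within the scatter). Compound 4 is therefore expected to give about 14000000 nM in this assay, with a range from 5000000 nM to 40000000 nM, the spread reflecting that the change is unlike any measured step.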

Compound 4, half-maximal inhibitory concentration: > 100000000 nM
Compound 4 was reported as a limit; the forecaster's own chance of this, stated with the estimate: 25%; middle value at least 7.1-fold (0.85 log units) from the limit.
By their numbers in this assay, from the lowest: compounds 1, 2 and 3 (each within the scatter of the next). At a limit, above all of these: compound 4.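

In this assay compound 4 is reported as a limit, > 100000000 nM, not as a number. Hydroxy in place of the group of 9 heavy atoms, on a carbonyl carbon whose other neighbours are: double-bonded chain carbon, gives the first step of the series beyond the scatter, an at least 6.9-fold higher number from compound 2 to compound 4 (0.84 log units; beyond the scatter), and its size is bounded on one side only: the limit of > 100000000 nM in this assay, at which 1 of the 4 values shown sits. Among the compounds shown here, the exchange on the other carbonyl carbon, a 1.5-fold higher number from compound 1 to compound 2 (0.17 log units; within the scatter), stayed within the scatter, so the two carbonyl carbons do not answer alike in this assay, and this is the first position where a change separates two compounds on this read-out.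

It remains open how much of the group of 9 heavy atoms is needed on this carbonyl carbon, since only its full length and hydroxy are shown there, with nothing in between such as a primary amide, a shorter or longer chain, or a chain ending in an amine. Also open, going by these compounds, is whether a methyl ester on this carbonyl carbon would stay with compound 2 or go with compound 4.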